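The compounds below may be only part of what the source reports. "The series", "measured", "known", "first", "only" and "open" are said of these compounds alone.

Measured so far in an assay for displacement of a labelled ligand from Adrenergic receptor alpha-1 (Homo sapiens); on this read-out higher numbers stand for weaker inhibition and lower numbers for stronger inhibition:
compound 1 `CCOc1ccccc1N1CCN(CCCCn2ncc(=O)n(C)c2=O)CC1` gives 1.8 nM
compound 2 `Cn1c(=O)cnn(CCCCN2CCN(c3ccccc3OCCCF)CC2)c1=O` gives 280 nM

Compound 2 stands as the higher of the two numbers, with compound 1 a long way below it; the step of a 160-fold higher number from compound 1 to compound 2 (2.19 log units; beyond the scatter) is the only measured one, and it lies far beyond the scatter. Compound 3 `CN(C)c1ccccc1N1CCN(CCCCn2ncc(=O)n(C)c2=O)CC1` is not yet measured. It differs from compound 2 in one place: dimethylamino in place of 3-fluoropropoxy on an aromatic carbon. Among the measured compounds shown here, no measured step covers this exact swap. The step from compound 1 to compound 2 does bear on it, since it alters the same group on the same aromatic carbon, and it shows that a small change at this position can move the number a long way. The group that enters in compound 3 has fewer heavy atoms than the one that leaves and is closer in size to the group carried by compound 1, so the number is expected to move back down, though not necessarily all the way. Compound 3 is therefore estimated at 10 nM in this assay, within 2 nM to 60 nM. This amounts to an expected step of a 28-fold lower number from compound 2 to compound 3 (1.45 log units; beyond the scatter), a decrease beyond the scatter.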

Compound 3, inhibition constant: 350 nM
Compound 3: middle estimate off by 35-fold (1.54 log units), on the low side, outside the stated range (above it).
By their numbers in this assay, from the lowest: compound 1; then compounds 2 and 3 (each within the scatter of the next).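

In this assay, putting dimethylamino in place of 3-fluoropropoxy on this aromatic carbon gives a 1.3-fold higher number from compound 2 to compound 3 (0.10 log units; within the scatter), so a group with fewer heavy atoms did not bring the number back towards that of compound 1. Set directly against ethoxy, dimethylamino gives a 190-fold higher number from compound 1 to compound 3 (2.29 log units; beyond the scatter), a large step like a 160-fold higher number from compound 1 to compound 2 (2.19 log units; beyond the scatter), so among these three groups only ethoxy goes with a low number, and heavy-atom count alone does not put them in order. Nothing measured here explains why dimethylamino and 3-fluoropropoxy stand so far from ethoxy.

The compounds shown leave open whether the low number depends on an oxygen joined directly to this carbon together with a short chain, something that methoxy or an unfluorinated propoxy would test, or on ethoxy alone. They also leave open whether the fluorine matters in the longer chain, and whether an ethylamino group, which keeps a nitrogen on this carbon but has the chain shape of ethoxy, would sit with compound 1 or with the other two.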